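The source may hold more compounds than are shown below. What is called first, only, known or untested is meant among the compounds shown, and "the series" means these compounds.

Compounds measured in an assay for inhibition of Catechol O-methyltransferase (Rattus norvegicus), read by fluorescence and spectrophotometry; a higher number here means a weaker inhibitor, a lower number a stronger inhibitor:
Compound 1, `O=C(/C=C/c1ccoc1)c1cc(O)c(O)c([N+](=O)[O-])c1`: 290 nM
Compound 2, `CC(=O)N1N=C(c2cc(O)c(O)c([N+](=O)[O-])c2)CC1c1ccco1`: 180 nM
Compound 3, `CC(=O)N1N=C(c2cc(O)c(O)c([N+](=O)[O-])c2)CC1c1ccc(C#N)cc1`: 48 nM

Compound 1 gives the highest of the three numbers in this assay. Compound 2 sits nearest to it, and the gap between compound 1 and compound 2 lies within the scatter, so the two cannot be told apart. Among the measured compounds shown here, compound 3 lies furthest away, beyond the scatter, and the one step that has been measured, a 3.8-fold lower number from compound 2 to compound 3 (0.57 log units; beyond the scatter), is a modest one in which 4-cyanophenyl replaces furan-2-yl on a saturated ring carbon.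

Compound 4, `O=C(/C=C/c1ccco1)c1cc(O)c(O)c([N+](=O)[O-])c1`, has not yet been measured. It differs from compound 1 in one place: furan-2-yl in place of furan-3-yl on a double-bonded chain carbon bound to a double-bonded chain carbon. The same atoms are present in both, joined differently.

For the measured compounds named here, none of the measured steps bears on this change. Going by the values given here, the step from compound 2 to compound 3 swaps a furan for a 4-cyanophenyl on a saturated ring carbon, not one furan attachment for another on a chain carbon, and no pair among the measured compounds compares furan-3-yl with furan-2-yl. With nothing to point in either direction, compound 4 is expected to land close to compound 1, with a step of a 1.1-fold lower number from compound 1 to compound 4 (0.05 log units; within the scatter) that stays within the scatter. The estimate for compound 4 is therefore 260 nM, in a range from 100 nM to 700 nM.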

Compound 4, half-maximal inhibitory concentration: 230 nM
Estimate against measurement, compound 4: 1.1-fold (0.05 log units) above; measured number inside the range.
By their numbers in this assay, from the lowest: compound 3; then compounds 2, 4 and 1 (each within the scatter of the next).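

In this assay, moving the furan attachment gives a 1.3-fold lower number from compound 1 to compound 4 (0.10 log units; within the scatter) and stays within the scatter, so furan-2-yl and furan-3-yl on a double-bonded chain carbon bound to a double-bonded chain carbon cannot be told apart here. Among the compounds shown here, the earlier step compared a furan with 4-cyanophenyl on a saturated ring carbon, whereas this pair is the first to compare the two furan attachments directly, with the same atoms joined differently and the rest of the structure unchanged. No measurement is at hand that would explain this result.

As far as these compounds go, it remains open whether the same swap on the saturated ring carbon of compound 2 would also stay within the scatter, and whether 4-cyanophenyl on the chain carbon of compound 1 would give a change like a 3.8-fold lower number from compound 2 to compound 3 (0.57 log units; beyond the scatter) in that setting. The compounds shown also leave open how a thiophene ring or an unsubstituted phenyl would compare with either furan at this place on the chain.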